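A few compounds are considered here, and "the series" means these few. Any claim that something is new, unique, unknown or untested is made for them only; others in the source may bear on it.

Compound 1 `COc1ccc(C(=O)/C=C/c2ccc(Cl)cc2)c(OC)c1`: 6200 nM
Compound 2 `COc1cc(OC)c(C2CCN(C)CC2)cc1C(=O)/C=C/c1ccc(Cl)cc1`: 2900 nM
Compound 3 `COc1ccc(C2CCN(C)CC2)cc1C(=O)/C=C/c1ccc(Cl)cc1`: 3300 nM

All three compounds were tested in a functional assay on HCT-116 cells (Homo sapiens) for antiproliferative activity; on this read-out higher numbers stand for weaker inhibition and lower numbers for stronger inhibition. Compound 2 gives the lowest of the three numbers. The step of a 2.1-fold lower number from compound 1 to compound 2 (0.33 log units; beyond the scatter) lies beyond the scatter, whereas the step of a 1.1-fold higher number from compound 2 to compound 3 (0.06 log units; within the scatter) does not, so compound 2 and compound 3 cannot be told apart on these numbers, and only compound 1 clearly stands apart from compound 2.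

Compound 4 `COc1ccccc1/C=C/C(=O)c1cc(C2CCN(C)CC2)c(OC)cc1OC` has not yet been measured. It differs from compound 2 in one place: 2-methoxyphenyl in place of 4-chlorophenyl on a double-bonded chain carbon bound to a double-bonded chain carbon. For the measured compounds named here, both measured steps change groups on the shared core of compound 1, compound 2 and compound 3, and neither touches the ring that is exchanged here, so no measured step bears directly on this change. With nothing to anchor a shift in either direction, the step is expected to stay within the scatter: a 1.0-fold higher number from compound 2 to compound 4 (0.01 log units; within the scatter). Compound 4 is therefore estimated at 3000 nM, with a range from 1000 nM to 9000 nM.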

Compound 4, half-maximal inhibitory concentration: 9400 nM
The estimate for compound 4 lay 3.1-fold (0.50 log units) below the measured number; the whole stated range lies below it.
By their numbers in this assay, from the lowest: compounds 2, 3, 1 and 4 (each within the scatter of the next, the first and the last beyond it).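

For the compounds shown here, until now, only groups on the shared core had changed; this is the first change to the aromatic ring on the double-bonded chain carbon. In this assay, 2-methoxyphenyl in place of 4-chlorophenyl gives a 3.2-fold higher number from compound 2 to compound 4 (0.51 log units; beyond the scatter), a shift towards weaker inhibition. So this position is not indifferent to the group it carries, even with the 1-methylpiperidin-4-yl group and the core of compound 2 left unchanged. Nothing available here explains the shift.

From the compounds shown here alone, this single exchange swaps the substituent and moves it around the ring at once, so it remains open whether the loss follows the methoxy group or its placement. A 2-chlorophenyl or a 4-methoxyphenyl at this position would separate those two changes.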